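Bromo-to-methyl swap on the aryl ring of compound 1

A few compounds are considered here, and "the series" means these few. Any claim that something is new, unique, unknown or untested is made for them only; others in the source may bear on it.

Compound 1 `O=S(=O)(Nc1ccncc1Nc1cccc(Br)c1)C(F)(F)F` gives 27.1% in a functional assay on the whole organism (strain Wistar) with Rattus norvegicus as the target, with stated times of 30 min and 4 h, at a dose of 5 mg/kg by the intraperitoneal route (on this read-out higher numbers stand for a stronger effect at the one dose given and lower numbers for a weaker effect), and stands highest of the two numbers in hand; compound 3 `O=S(=O)(Nc1ccncc1Nc1ccc(F)c(Br)c1)C(F)(F)F` gives 11.1%, and compound 2 `Cc1ccc(Nc2cnccc2NS(=O)(=O)C(F)(F)F)cc1Br` is reported as "not active" (no number reported) without a number.

Among the measured compounds shown here, the single measured step with a number on both sides is a number 16 percentage points lower from compound 1 to compound 3 (beyond the scatter). The unmeasured compound 4 `Cc1cccc(Nc2cnccc2NS(=O)(=O)C(F)(F)F)c1` differs from compound 1 as follows: methyl in place of bromo on an aromatic carbon. For the measured compounds named here, no measured pair shows this change. The step from compound 1 to compound 3 is a different substitution and bears on it only in showing that a small change on this ring can move the read-out beyond the scatter. Compound 2, which carries an added methyl on the same ring next to the bromo of compound 1, shows no activity, a second hint that changes on this ring tend to lower the read-out.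

Given these, the expectation for compound 4 is a step of a number 10.1 percentage points lower from compound 1 to compound 4 (beyond the scatter), downward but uncertain. Compound 4 is estimated at 17%, with a range from 0% to 34%.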

Compound 4, a percentage reported as activity, at one dose (the size of the read-out at that dose, not a potency): 17.1%
Compound 4: the middle estimate sits 0.1 percentage points below what was measured, within the range that was stated.
By their numbers in this assay, from the lowest: compounds 3, 4 and 1 (each within the scatter of the next, the first and the last beyond it).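

At this place, on an aromatic carbon meta to a large group, methyl in place of bromo gives a number 10 percentage points lower from compound 1 to compound 4 (within the scatter), so this assay does not separate 3-bromophenyl from 3-methylphenyl. Bromine is therefore not needed here for a numbered read-out, and this change, unlike the fluoro step a number 16 percentage points lower from compound 1 to compound 3 (beyond the scatter), leaves no difference beyond the scatter. No measurement of any property of either group accompanies this result, and the data give no explanation for it.

On these data alone, whether an amine, a carboxylic acid or a longer chain at this place would keep the read-out in this assay remains open, as does the effect of plain hydrogen there. As far as these compounds go, each read-out comes from one dose, so how compound 1 and compound 4 compare in potency also remains open.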